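Urea series, permeability: methyl to chloro exchange

The source may report more compounds than this note shows. Statements on the series, on what has been measured and on what is new or still open speak of the compounds shown alone.

Measured compounds:
compound 1, `COc1ccc(NC(=O)Nc2cc(C)nc3ccccc23)cc1F`: 50 10^-6 cm/s
compound 2, `Cc1ccc(NC(=O)Nc2cc(C)nc3ccccc23)cc1`: 669 10^-6 cm/s

In an ADME assay for permeability, using PAMPA, at pH 7.4 (on this read-out lower numbers stand for lower permeability and higher numbers for higher permeability), compound 2 stands highest of the two numbers, with compound 1 well below it; the gap between them is clearly beyond the scatter. Compound 3, `Cc1cc(NC(=O)Nc2ccc(Cl)cc2)c2ccccc2n1`, is not yet measured. It differs from compound 2 by chloro in place of methyl on an aromatic carbon. Among the measured compounds shown here, no measured pair shows this exchange, so there is nothing to lean on beyond the change itself. The step from compound 2 to compound 3 is expected to stay within the scatter, estimated as a 1.1-fold lower number from compound 2 to compound 3 (0.05 log units; within the scatter). Compound 3 is therefore expected to give about 600 10^-6 cm/s, in a range from 300 10^-6 cm/s to 1200 10^-6 cm/s.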

Compound 3, apparent permeability: 537 10^-6 cm/s
For compound 3 the middle estimate is 1.1-fold (0.05 log units) above the measured one; the range from low to high includes it.
By their numbers in this assay, from the lowest: compound 1; then compounds 3 and 2 (each within the scatter of the next).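

In this assay chloro in place of methyl gives a 1.2-fold lower number from compound 2 to compound 3 (0.10 log units; within the scatter) on this aromatic carbon, para to a large group. Among the compounds shown here, this is the first reading of a single-place change, and at this position the two groups are not told apart on this read-out. Nothing measured here bears on why the exchange reads this way.

Open, as far as these compounds go, is how this position responds to a group of another kind, such as an amine, a carboxylic acid or a longer chain. Also open, from the compounds shown here alone, is whether the exchange reads the same with other groups elsewhere on the shared core.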